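This account rests on a few compounds, and the source may have more. Where it says the series, first, only, none or still open, it means among the compounds named here.

The measured compounds:

compound 1, `CN(C)C(=O)c1cc2cnc(Nc3ccc(C(=O)NCCCN=C=S)cc3)nc2n1C1CCCC1`, 32.9%
compound 2, `CN(C)C(=O)c1cc2cnc(Nc3ccc(C(=O)NCCCCN=C=S)cc3)nc2n1C1CCCC1`, 30.2%
compound 3, `CN(C)C(=O)c1cc2cnc(Nc3ccc(C(=O)NCCCCCN=C=S)cc3F)nc2n1C1CCCC1`, -1.6%

In a functional assay on A549 cells (Homo sapiens) for inhibition, read by CCK-8 assay, with a stated time of 72 h, tested at 1 uM (on this read-out higher numbers stand for a stronger effect at the one concentration tested and lower numbers for a weaker effect), compound 1 gives 32.9%. Compound 2 differs from it by a group of 4 heavy atoms (2 carbon, 1 nitrogen, 1 sulfur; no ring) in place of a group of 3 heavy atoms (1 carbon, 1 nitrogen, 1 sulfur; no ring), on a saturated chain carbon, three bonds along the chain from an amide-type nitrogen, and in this assay compound 2 gives 30.2%, so the step is a number 2.7 percentage points lower from compound 1 to compound 2 (within the scatter). The two values therefore sit within the scatter of each other and no order between compound 1 and compound 2 can be read from them.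

Compound 3 belongs to a second core; how the core of compound 3 differs from the core of compound 1 is not broken down here. In this assay compound 3 gives -1.6%, which is the lowest of the three numbers, and its gap to compound 2 and to compound 1 lies beyond the scatter.

Compound 4, `CN(C)C(=O)c1cc2cnc(Nc3ccc(C(=O)NCCCCCCN=C=S)cc3F)nc2n1C1CCCC1`, has not yet been measured. It differs from compound 3 by a group of 4 heavy atoms (2 carbon, 1 nitrogen, 1 sulfur; no ring) in place of a group of 3 heavy atoms (1 carbon, 1 nitrogen, 1 sulfur; no ring), on a saturated chain carbon, five bonds along the chain from an amide-type nitrogen. For the measured compounds named here, this is the same kind of change as the one from compound 1 to compound 2, but not the same: there the place was three bonds along the chain from an amide-type nitrogen, here it is five bonds along the chain from an amide-type nitrogen. Compound 4 is expected to move from compound 3 by about a number 1.4 percentage points lower from compound 3 to compound 4 (within the scatter), because a number 2.7 percentage points lower from compound 1 to compound 2 (within the scatter) was a small step, and the core of compound 3 is the other point of reference. The estimate for compound 4 in this assay is -3%, expected to fall between -15% and 12%.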

Compound 4, a percentage reported as inhibition, at one concentration (the size of the read-out at that concentration, not a potency): -11.8%
Compound 4: the middle estimate sits 8.8 percentage points above what was measured, and the stated range covers the measured number.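

In this assay, putting the group of 4 heavy atoms in place of the group of 3 heavy atoms on the core of compound 3 gives a number 10.2 percentage points lower from compound 3 to compound 4 (beyond the scatter), a modest step that lies beyond the scatter, whereas the same kind of change on the core of compound 1 stayed within it. Even so, the two steps cannot be told apart, so the data give no sign that the core alters the effect of this change: the same change on two cores in this assay, a number 2.7 percentage points lower (within the scatter) from compound 1 to compound 2 and a number 10.2 percentage points lower (beyond the scatter) from compound 3 to compound 4, 7.5 percentage points apart, within the scatter of two such steps This does not show that the effect is the same on both cores, since each core offers a single pair and the change sits three bonds along the chain from an amide-type nitrogen in one pair and five bonds along it in the other, so core and chain place cannot be separated.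

The compounds shown leave open how the same chain lengths would read on each of the two cores, and whether a still longer chain would continue the step seen here. They also leave open how this read-out would respond if an amine or a carboxylic acid stood at the end of the chain in place of the present group.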